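This account rests on a few compounds, and the source may have more. Where it says the series, first, only, none or still open, it means among the compounds named here.

The three measured compounds share one core and differ only in a group on an aromatic carbon of a six-membered aromatic ring of carbon only. Compound 1 `CCOC(=O)c1c(-c2ccccc2)[nH]c2cc(OC)ccc2c1=O` carries hydrogen there, compound 2 `CCOC(=O)c1c(-c2cccc(-c3ccccc3)c2)[nH]c2cc(OC)ccc2c1=O` a phenyl, and compound 3 `CCOC(=O)c1c(-c2cccc(OC(F)(F)F)c2)[nH]c2cc(OC)ccc2c1=O` a trifluoromethoxy. In an ADME assay on HEK293 cells (Homo sapiens) for cytotoxicity, read by luminescence, with a stated time of 72 h (a higher number here means that more compound is needed for the effect, a lower number that less compound is needed), compound 1 gives > 22000 nM, which is a limit of the assay and not a number. Compound 2 gives > 22000 nM, again a limit. Compound 3 gives > 22000 nM, also a limit. Because (the limit of > 22000 nM in this assay, at which 3 of the 3 values shown sit), the steps a step that the two limits leave unreadable from compound 1 to compound 2, a step that the two limits leave unreadable from compound 1 to compound 3 and a step that the two limits leave unreadable from compound 2 to compound 3 cannot be read in size. Compound 2 therefore stands only at a limit, with no number to place it among the others.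

Compound 4 `CCOC(=O)c1c(-c2cccc(C(F)(F)F)c2)[nH]c2cc(OC)ccc2c1=O` is still to be measured. The change is trifluoromethyl in place of phenyl on an aromatic carbon. The closest measured comparison, a step that the two limits leave unreadable from compound 2 to compound 3, also removes the phenyl, yet its size is unreadable. On this basis no step beyond the scatter can be expected in either direction. Compound 4 is expected to give 30000 nM, between 22000 nM and 150000 nM, most likely as another limit. The expected step that the limit leaves unreadable from compound 2 to compound 4 is thus small or none.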

Compound 4, half-maximal effective concentration: > 22000 nM
Compound 4 gave a limit, no number; the forecaster's own chance of this, stated with the estimate: 85%; the middle value lies beyond the limit too.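

The steps to compound 4 from compound 1, compound 2 and compound 3 cannot be read in size, because all four compounds share one limit: the limit of > 22000 nM in this assay, at which 4 of the 4 values shown sit. The compounds shown leave open whether any of these groups changes the concentration needed in this assay, and by how much.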